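From Hydroxy to Fluoro: Estimating Compound 4

The compounds below may be only part of what the source reports. "The series", "measured", "known", "first", "only" and "open" are said of these compounds alone.

compound 1 `Cc1cccc(NC(=O)CN2CCC(c3ccccc3C#N)CC2)c1`: 8 nM
compound 2 `Cc1cccc(NC(=O)CN2CCC(c3cccc(O)c3)CC2)c1`: 8 nM
compound 3 `O=C(NCN1CCC(c2cccc[n+]2[O-])CC1)c1ccc2ccccc2c1`: 115 nM

Of the compounds shown here, three have been measured in a functional assay on HEK293 cells for agonist activity at D(4) dopamine receptor (Homo sapiens), read by FLIPR; a higher number here means that more compound is needed for the effect, a lower number that less compound is needed. Compound 2 stands level with compound 1, the two together being the lowest numbers of the set, and it is separated from compound 3 by a gap that lies well beyond the scatter, compound 3 giving 115 nM. Going by the values given here, the one single-point step among the measured compounds runs no change at the digits printed from compound 1 to compound 2 (within the scatter), so replacing 2-cyanophenyl with 3-hydroxyphenyl on the saturated ring carbon left the readout unchanged within the scatter.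

Compound 4 `Cc1cccc(NC(=O)CN2CCC(c3cccc(F)c3)CC2)c1` is not yet measured. It differs from compound 2 by fluoro in place of hydroxy on an aromatic carbon. Among the compounds with values here, no measured pair shows this exact exchange; the closest guide is the step from compound 1 to compound 2, which shows that a change of the group on that aromatic ring can pass without any shift beyond the scatter. On that basis the swap of hydroxy for fluoro is expected to move the number little, if at all.

Compound 4 is therefore estimated at 10 nM, with a range from 3 nM to 35 nM. The expected step is a 1.3-fold higher number from compound 2 to compound 4 (0.10 log units; within the scatter), that is, none beyond the scatter.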

Compound 4, half-maximal effective concentration: 512 nM
Estimate against measurement, compound 4: 51-fold (1.71 log units) below, outside the stated range (above it).
By their numbers in this assay, from the lowest: compounds 1 and 2 (each within the scatter of the next); then compound 3; then compound 4.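

In this assay the exchange on this aromatic carbon proved far from neutral, since fluoro in place of hydroxy brings a 64-fold higher number from compound 2 to compound 4 (1.81 log units; beyond the scatter) and so shows a sensitivity that the earlier step, no change at the digits printed from compound 1 to compound 2 (within the scatter) with its exchange of 2-cyanophenyl for 3-hydroxyphenyl, had not revealed. The 3-fluorophenyl group also parts from the 2-cyanophenyl group, with a 64-fold higher number from compound 1 to compound 4 (1.81 log units; beyond the scatter) in this assay, so two of these aryl groups stand level while the third does not, and a small exchange of one heavy atom for another is enough to separate them. The change removes the hydrogen-bond donor and acceptor counted for hydroxy, but nothing available explains the shift or ties it to those counts.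

The compounds shown leave open whether an amine or methoxy on the same aromatic carbon would stay close to compound 2 or move towards compound 4. They also leave open whether chloro or a nitrile there would give a number like that of fluoro, and so whether fluoro is a special case or one of many groups that behave alike.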